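Methyl for hydrogen on the fused ring of compound 1

The compounds below may be only part of what the source reports. "The series", "measured", "known", "first", "only" and "open" are said of these compounds alone.

Compound 1 `O=c1cc(-c2ccccc2)oc2cc(N3COc4ccccc4C3)ccc12` sits second highest of the three numbers in hand: in a functional assay on MCF7 cells (Homo sapiens) for inhibition, read by MTT assay, with a stated time of 48 h, tested at 30 ug/mL (a higher number here means more inhibition of growth at the concentration tested, a lower number less inhibition of growth), compound 1 gives 12.7%. Compound 2 `O=c1cc(-c2ccccc2)oc2cc(N3COc4c(Br)cc(Br)cc4C3)ccc12`, the dibromo analogue, gives 11.1% in this assay, a number within the scatter of compound 1. Compound 3 `COc1cccc2c1OCN(c1ccc3oc(-c4ccccc4)cc(=O)c3c1)C2`, which carries a methoxy group on the shared core, gives 67.8% in this assay, far beyond the scatter above compound 1. No two of these compounds differ in a single place, so no measured step is available.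

Compound 4 `Cc1cccc2c1OCN(c1ccc3c(=O)cc(-c4ccccc4)oc3c1)C2` is the next compound, not yet measured. It differs from compound 1 as follows: methyl in place of hydrogen on an aromatic carbon. Methyl is a small group; the only substituted analogue that rises clearly is compound 3 with its 67.8%, while compound 2 with 11.1% does not. Among the compounds with values here, a moderate upward step is expected, but with wide uncertainty, since the step expected from compound 1 to compound 4 of a number 12.3 percentage points higher from compound 1 to compound 4 (beyond the scatter) rests on no direct precedent. In this assay compound 4 is estimated at 25%, with a range from 8% to 55%.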

Compound 4, percent growth inhibition at one concentration: 57.8%
Estimate against measurement, compound 4: 32.8 percentage points below; the measured number lies above the stated range.
By their numbers in this assay, from the lowest: compounds 2 and 1 (each within the scatter of the next); then compounds 4 and 3 (each within the scatter of the next).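

In this assay, within the data shown here, the replacement of hydrogen by methyl on this aromatic carbon gives a number 45.1 percentage points higher from compound 1 to compound 4 (beyond the scatter) and is the only single-place change read so far. The position, on the six-membered aromatic ring of carbon only, ortho to a fused ring and meta to a fused ring, is therefore sensitive to substitution: a single added carbon moves the result well beyond the scatter. Nothing at hand accounts for the size of this step, and no measured property of the compounds bears on it.

From the compounds shown here alone, whether the rise is particular to methyl remains open, as ethyl, chlorine, hydroxyl or an amine on the same carbon would be needed to tell. Also open, going by these compounds, is whether methyl on the other aromatic carbons of that ring would give a step of similar size.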